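Swapping the Methylphenyl of Compound 3 for a Cyanophenyl

This account rests on a few compounds, and the source may have more. Where it says the series, first, only, none or still open, it means among the compounds named here.

Three measured compounds share one core and differ only in the aryl group attached on an aromatic carbon of the five-membered ring with four nitrogens. Compound 1 `Cc1cc(NC(=O)Cn2nnc(-c3ccccn3)n2)n(C2CCCCC2)n1` carries pyridin-2-yl; in an assay on HEK293 cells for activation of Kir3.1/Kir3.2 (Homo sapiens), read by thallium flux (a higher number here means that more compound is needed for the effect, a lower number that less compound is needed), compound 1 gives 14600 nM. Compound 2 `Cc1cc(NC(=O)Cn2nnc(-c3cc(Cl)cc(Cl)c3)n2)n(C2CCCCC2)n1` carries 3,5-dichlorophenyl, and in this assay compound 2 gives 980 nM. Compound 3 `Cc1ccc(-c2nnn(CC(=O)Nc3cc(C)nn3C3CCCCC3)n2)cc1` carries 4-methylphenyl, and in this assay compound 3 gives 111 nM, the lowest of the three numbers; the steps of a 130-fold lower number from compound 1 to compound 3 (2.12 log units; beyond the scatter) and an 8.8-fold lower number from compound 2 to compound 3 (0.95 log units; beyond the scatter) show that this aryl group moves the result strongly. Compound 4 `Cc1cc(NC(=O)Cn2nnc(-c3cccc(C#N)c3)n2)n(C2CCCCC2)n1` is the next variation: 3-cyanophenyl in place of 4-methylphenyl on an aromatic carbon. Within the data shown here, no measured step exchanges a methyl for a nitrile, so the closest guide is an 8.8-fold lower number from compound 2 to compound 3 (0.95 log units; beyond the scatter), where a differently substituted phenyl replaced 4-methylphenyl, together with a 15-fold lower number from compound 1 to compound 2 (1.17 log units; beyond the scatter). Since both other aryl groups gave higher numbers than compound 3, a modest rise is expected, with much uncertainty. Compound 4 is therefore estimated to give 1500 nM, within a range from 300 nM to 8000 nM, an expected step of a 14-fold higher number from compound 3 to compound 4 (1.13 log units; beyond the scatter).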

Compound 4, half-maximal effective concentration: 183 nM
Beside the measured number, compound 4's estimate is 8.2-fold (0.91 log units) above it, outside the stated range (below it).
By their numbers in this assay, from the lowest: compounds 3 and 4 (each within the scatter of the next); then compound 2; then compound 1.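

In this assay, 3-cyanophenyl and 4-methylphenyl cannot be told apart (a 1.6-fold higher number from compound 3 to compound 4 (0.22 log units; within the scatter)), so at this position on the ring with four nitrogens a nitrile-bearing phenyl serves as well as a methyl-bearing one. A low number here is therefore not tied to 4-methylphenyl alone, since 3-cyanophenyl also stands clearly apart from 3,5-dichlorophenyl (a 5.4-fold lower number from compound 2 to compound 4 (0.73 log units; beyond the scatter)) and from pyridin-2-yl (an 80-fold lower number from compound 1 to compound 4 (1.90 log units; beyond the scatter)). Nothing available explains why these two different phenyl groups give matching results.

Compound 4 differs from compound 3 in both the substituent and its numbered place on the phenyl, so only 3-methylphenyl and 4-cyanophenyl could separate those two changes. Also open, from the compounds shown here alone, is how this position would respond to a phenyl carrying an amine or a carboxylic acid.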